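This account rests on a few compounds, and the source may have more. Where it says the series, first, only, none or still open, it means among the compounds named here.

Compound 1, `C/N=C(/NC#N)NCCCCn1nc(-c2ccc(C)cc2)ccc1=O`, has the higher of the two numbers measured in a functional assay on the whole organism with Rattus norvegicus as the target, at a dose of 100 mg/kg; a lower number here means less inhibition, a higher number more inhibition at the dose given (going by the name of the read-out): there compound 1 gives 45.7%, while compound 2, `CCC/N=C(/NC#N)NCCCn1nc(C)ccc1=O`, gives 17.5%, a gap beyond the usual scatter. Compound 3, `C/N=C(/NC#N)NCCCCn1nc(-c2ccc(Cl)cc2)ccc1=O`, differs from compound 1 by chloro in place of methyl on an aromatic carbon. Going by the values given here, with no measured pair showing this exchange, the step is expected to stay small, with no clear direction beyond the scatter, so the change from compound 1 to compound 3 in this assay is estimated at a number 2.3 percentage points higher from compound 1 to compound 3 (within the scatter). Compound 3 is accordingly expected to give 48%, likely between 30% and 65%.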

Compound 3, a percentage reported as inhibition, in the whole organism at one dose (the size of the read-out at that dose, not a potency): 51%
For compound 3 the middle estimate is 3 percentage points below the measured one; low and high end bracket the measured number.
By their numbers in this assay, from the lowest: compound 2; then compounds 1 and 3 (each within the scatter of the next).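

Exchanging 4-methylphenyl for 4-chlorophenyl gives, in this assay, a number 5.3 percentage points higher from compound 1 to compound 3 (within the scatter). Going by these compounds alone, at this position, on the aromatic carbon para to a large group, methyl and chloro therefore cannot be told apart in this assay, which is the first direct reading of this exchange. No measurement of any property of these groups bears on this result. The compounds shown leave open how a methoxy group, an amine or a plain hydrogen would read at this same position, and what a longer chain on the shared core would do.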